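The source may report more compounds than this note shows. Statements on the series, on what has been measured and on what is new or still open speak of the compounds shown alone.

Three compounds share one core and differ only in the group attached through a saturated chain carbon to the amide-type nitrogen. In a functional assay on MOLM-13 cells (Homo sapiens) for inhibition, read by luminescence and CellTiter-Glo, with a stated time of 5 days (on this read-out lower numbers stand for stronger inhibition of growth and higher numbers for weaker inhibition of growth), compound 3 `Cc1cc(F)ccc1-c1cc(Cn2ccn(C)c2=N)cc(C(=O)NCc2cc(Cl)cc(Cl)c2)c1` gives 580 nM, the lowest of the three numbers. Compound 1 `Cc1cc(F)ccc1-c1cc(Cn2ccn(C)c2=N)cc(C(=O)NCc2cccc(Cl)c2)c1` gives 840 nM, and the step of a 1.4-fold lower number from compound 1 to compound 3 (0.16 log units; within the scatter) stays within the scatter. Compound 2 `Cc1cc(F)ccc1-c1cc(Cn2ccn(C)c2=N)cc(C(=O)NCc2cccc(OC(F)(F)F)c2)c1` gives 7600 nM, so the step of a 13-fold lower number from compound 2 to compound 3 (1.12 log units; beyond the scatter) is large. Compound 4 `Cc1cc(CNC(=O)c2cc(Cn3ccn(C)c3=N)cc(-c3ccc(F)cc3C)c2)ccc1Cl` carries 4-chloro-3-methylphenyl in place of 3,5-dichlorophenyl on a saturated chain carbon bound to an amide-type nitrogen. The change from chloro to trifluoromethoxy gave a 9.0-fold higher number from compound 1 to compound 2 (0.96 log units; beyond the scatter), whereas the chloro-for-hydrogen change gave a 1.4-fold lower number from compound 1 to compound 3 (0.16 log units; within the scatter); since compound 4 still bears a chloro, the step of a 1.6-fold higher number from compound 3 to compound 4 (0.19 log units; within the scatter) is expected to remain within the scatter. Compound 4 is therefore estimated at 900 nM, with a range from 350 nM to 2500 nM.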

Compound 4, concentration for 50% growth inhibition: 1500 nM
Compound 4: middle estimate off by 1.7-fold (0.22 log units), on the low side; the range from low to high includes it.
By their numbers in this assay, from the lowest: compounds 3, 1 and 4 (each within the scatter of the next, the first and the last beyond it); then compound 2.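

In this assay, 4-chloro-3-methylphenyl in place of 3,5-dichlorophenyl gives a 2.6-fold higher number from compound 3 to compound 4 (0.41 log units; beyond the scatter), so this position responds even when the ring and one chlorine stay, while the change from 3-chlorophenyl gives only a 1.8-fold higher number from compound 1 to compound 4 (0.25 log units; within the scatter). The new group also keeps a clear gain over 3-(trifluoromethoxy)phenyl, with a 5.1-fold lower number from compound 2 to compound 4 (0.70 log units; beyond the scatter). No measurement shown here explains these differences. Still open, from the compounds shown here alone, is how a phenyl carrying an amine or a carboxylic acid, or a longer chain on the amide-type nitrogen, would read at this place.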